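The source may report more compounds than this note shows. Statements on the series, on what has been measured and on what is new or still open speak of the compounds shown alone.

Compound 1, `O=c1[nH]cc(S(=O)(=O)Nc2ccccc2-c2cn(-c3ccccc3F)nn2)c(=O)[nH]1`, and compound 2, `O=c1[nH]cc(S(=O)(=O)Nc2ccccc2-c2cn(-c3ccc(F)cc3)nn2)c(=O)[nH]1`, share the same core and differ only in where a fluorine sits on the phenyl ring attached to the triazole nitrogen. In a functional assay on SGC-7901 cells (Homo sapiens) for antiproliferative activity, read by MTT assay, with a stated time of 24 h (on this read-out lower numbers stand for stronger inhibition and higher numbers for weaker inhibition), compound 1 gives 10800 nM. Compound 2 reaches only the limit of this assay, > 20000 nM, so no plain number is known for it. The step of an at least 1.8-fold higher number from compound 1 to compound 2 (0.26 log units; that floor lies within the scatter) therefore rests on a limit, as does the evidence (the limit of > 20000 nM in this assay, at which 1 of the 3 values shown sits). Compound 3, `Cc1cccc(-n2cc(-c3cccc(NS(=O)(=O)c4c[nH]c(=O)[nH]c4=O)c3)nn2)c1`, carries a 3-methylphenyl on the triazole, and in this assay compound 3 gives 9100 nM; of the two plain numbers available, this value and that of compound 1 lie within the scatter of each other, so neither can be called stronger.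

Compound 4, `O=c1[nH]cc(S(=O)(=O)Nc2cccc(-c3cn(-c4cccc(Cl)c4)nn3)c2)c(=O)[nH]1`, differs from compound 3 by chloro in place of methyl on an aromatic carbon. Among the measured compounds shown here, no measured step swaps a methyl for a chloro; the only measured step, from compound 1 to compound 2, moves a fluorine and sits at a floor within the scatter. For the measured compounds named here, with no step of this kind to lean on, the change is expected to stay within the scatter in this assay, giving an expected step of a 1.0-fold lower number from compound 3 to compound 4 (0.00 log units; within the scatter). Compound 4 is therefore estimated at 9000 nM, in the range 4000 nM to 20000 nM.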

Compound 4, half-maximal inhibitory concentration: 3950 nM
Estimate against measurement, compound 4: 2.3-fold (0.36 log units) above; measured number below the stated range.
By their numbers in this assay, from the lowest: compound 4; then compounds 3 and 1 (each within the scatter of the next). At a limit, above all of these: compound 2.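

The change from 3-methylphenyl to 3-chlorophenyl gives, in this assay, a 2.3-fold lower number from compound 3 to compound 4 (0.36 log units; beyond the scatter) and is the first single change shown here that clears the usual scatter. This makes the aromatic carbon meta to a large group a place where exchanging one heavy atom for another can shift the number, if only modestly, whereas the fluorine move from compound 1 to compound 2 rests on a floor that lies within the scatter. Nothing measured here accounts for the lower number with chloro, and the only recorded limit concerns a different compound.

Going by these compounds, it remains open whether other groups on this same carbon, such as a bromo, a methoxy or an amine, would lower the number further, raise it or leave it unchanged. This is also a single pair of compounds, so it cannot show whether chloro in place of methyl would give a similar step on another ring or at another place on this one.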